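The compounds below may be only part of what the source reports. "The series", "measured", "known", "first", "only" and "open" are said of these compounds alone.

Series notes, measured and pending:
- Compound 1 `COc1ccc(/C=C2\CCC/C(=C\c3cccc(OC)c3OC)C2=O)cc1OC`: 6400 nM
- Compound 2 `COc1cc(/C=C2\CCC/C(=C\c3cccc(OC)c3OC)C2=O)cc(OC)c1`: 3800 nM
- Compound 3 `COc1cccc(/C=C2\CCC/C(=C\c3cc(OC)c(OC)c(OC)c3)C2=O)c1OC`: not yet measured

In a functional assay on SW-620 cells (Homo sapiens) for cytotoxicity, read by MTT assay, with a stated time of 72 h (on this read-out higher numbers stand for weaker inhibition and lower numbers for stronger inhibition), compound 2 gives 3800 nM and compound 1 gives 6400 nM. These two values lie within the usual scatter of each other, so compound 2 cannot be ranked apart from compound 1 on these numbers.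

Compound 3 differs from compound 2 in one place: methoxy in place of hydrogen on an aromatic carbon. This puts methoxy in place of hydrogen on an aromatic carbon, ortho to two methoxy groups and para to a large group.

Within the data shown here, the measured compounds offer no step that differs in one place, so there is no direct precedent for this change. The expectation in this assay is therefore a small step at most, with a slight lean towards a lower number. Compound 2 at 3800 nM is the anchor for this expectation. The estimated 1.4-fold lower number from compound 2 to compound 3 (0.13 log units; within the scatter) is expected to stay within the scatter. For compound 3 the estimate is 2800 nM, with an expected range of 1000 nM to 7500 nM.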

Compound 3, half-maximal inhibitory concentration: 2500 nM
For compound 3 the middle estimate is 1.1-fold (0.05 log units) above the measured one; the range from low to high includes it.
By their numbers in this assay, from the lowest: compounds 3, 2 and 1 (each within the scatter of the next, the first and the last beyond it).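

In this assay methoxy in place of hydrogen on an aromatic carbon, ortho to two methoxy groups and para to a large group, gives a 1.5-fold lower number from compound 2 to compound 3 (0.18 log units; within the scatter) and so leaves the read-out unresolved from compound 2 at this position: the carbon accepts the added group, but no change can be claimed from this step alone. Among these compounds, the same kind of replacement elsewhere on that ring gives a 2.6-fold lower number from compound 1 to compound 3 (0.41 log units; beyond the scatter) as a modest step, the only step that lies beyond the scatter, so the replacement does not read the same at every carbon of the ring, although the gap between the two steps is not itself established. The data on hand offer no measurement that accounts for either step.

The compounds shown carry only methoxy on these rings, which leaves open whether the modest step belongs to methoxy itself or would also appear with a hydroxy group, an amine, a fluorine atom or the longer ethoxy chain. Also open, on these data alone, is whether the step holds once the other ring, the same in all three compounds, is changed.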